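From Dichlorophenyl to Thiophene on the Amide Carbonyl

A few compounds are considered here, and "the series" means these few. Any claim that something is new, unique, unknown or untested is made for them only; others in the source may bear on it.

Three analogues of one shared core have been measured. In a functional assay on SiHa cells (Homo sapiens) for inhibition (on this read-out higher numbers stand for weaker inhibition and lower numbers for stronger inhibition), compound 1 `COc1cc(/C=C/C(=O)c2cccc(NC(=O)c3ccco3)c2)ccc1O` gives 0.76 ug/mL, compound 2 `COc1cc(/C=C/C(=O)c2cccc(NC(=O)C(C)C)c2)ccc1O` gives 5.96 ug/mL, and compound 3 `COc1cc(/C=C/C(=O)c2cccc(NC(=O)c3cc(Cl)cc(Cl)c3)c2)ccc1O` gives 17.7 ug/mL. Compound 3 thus carries the highest number of the three: its nearest neighbour is compound 2, as a 3.0-fold higher number from compound 2 to compound 3 (0.47 log units; beyond the scatter) shows, and the gap a 23-fold higher number from compound 1 to compound 3 (1.37 log units; beyond the scatter) is larger. Compound 4 `COc1cc(/C=C/C(=O)c2cccc(NC(=O)c3cccs3)c2)ccc1O` awaits measurement and differs from compound 3 in one place: thiophen-2-yl in place of 3,5-dichlorophenyl on a carbonyl carbon. The step of a 23-fold higher number from compound 1 to compound 3 (1.37 log units; beyond the scatter) bears most directly on this change, since compound 1 carries furan-2-yl on the same carbonyl carbon. Compound 4 is therefore expected to give a clearly lower number in this assay, an estimated step of a 15-fold lower number from compound 3 to compound 4 (1.17 log units; beyond the scatter). The value of compound 4 is estimated at 1.2 ug/mL, within a range from 0.4 ug/mL to 4 ug/mL.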

Compound 4, half-maximal inhibitory concentration: 6.57 ug/mL
Estimate against measurement, compound 4: 5.5-fold (0.74 log units) below; the measured number lies above the stated range.
By their numbers in this assay, from the lowest: compound 1; then compounds 2 and 4 (each within the scatter of the next); then compound 3.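

In this assay, the two five-membered aromatic rings on this carbonyl carbon do not read alike: thiophen-2-yl in place of furan-2-yl gives an 8.6-fold higher number from compound 1 to compound 4 (0.94 log units; beyond the scatter). Replacing 3,5-dichlorophenyl with thiophen-2-yl gives a 2.7-fold lower number from compound 3 to compound 4 (0.43 log units; beyond the scatter), yet thiophen-2-yl in place of isopropyl gives only a 1.1-fold higher number from compound 2 to compound 4 (0.04 log units; within the scatter), so among these compounds, carrying an aromatic ring does not by itself set the number. Nothing available here accounts for the gap between furan-2-yl and thiophen-2-yl.

Going by these compounds, whether the low number of compound 1 belongs to furan-2-yl alone remains open. So does how furan-3-yl, an oxazole ring or a carboxylic acid would read on this carbonyl carbon.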